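Butyl for bromophenyl on a triazole-bearing butenolide

A few compounds are considered here, and "the series" means these few. Any claim that something is new, unique, unknown or untested is made for them only; others in the source may bear on it.

Measured compounds:
- compound 1, `O=C1O[C@H]([C@@H](O)Cn2cc(-c3ccc(Br)cc3)nn2)C(OCc2ccccc2)=C1OCc1ccccc1`: 5070 nM
- compound 2, `Cc1ccc(-c2cn(C/C=C3\OC(=O)C(OCc4ccccc4)=C3OCc3ccccc3)nn2)cc1`: > 100000 nM

Within the data shown here, in a functional assay on HepG2 cells (Homo sapiens) for antiproliferative activity, read by MTT assay, with a stated time of 72 h (on this read-out lower numbers stand for stronger inhibition and higher numbers for weaker inhibition), compound 1 gives 5070 nM, the only actual number in hand. Compound 2 yields only a limit, > 100000 nM, in this assay; that is the limit of > 100000 nM in this assay, at which 1 of the 2 values shown sits. Compound 1 therefore stands alone as the single quantified point.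

Compound 3, `CCCCc1cn(C[C@H](O)[C@H]2OC(=O)C(OCc3ccccc3)=C2OCc2ccccc2)nn1`, differs from compound 1 by one change: butyl in place of 4-bromophenyl on an aromatic carbon. Among the measured compounds shown here, no measured pair shows this kind of step. The step from compound 1 to compound 3 is expected to weaken inhibition somewhat, a 3.0-fold higher number from compound 1 to compound 3 (0.47 log units; beyond the scatter), though it may stay within the scatter. Compound 3 is estimated at 15000 nM, with a range from 4000 nM to 60000 nM.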

Compound 3, half-maximal inhibitory concentration: 32800 nM
For compound 3 the middle estimate is 2.2-fold (0.34 log units) below the measured one; low and high end bracket the measured number.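

Butyl in place of 4-bromophenyl gives the first readable step at this aromatic carbon, a 6.5-fold higher number from compound 1 to compound 3 (0.81 log units; beyond the scatter), so in this assay this position responds to the change. Compound 3 still gives a quantified value, 32800 nM, so this pair shows that measurable inhibition does not depend on an aromatic ring at this carbon. Nothing in hand accounts for the size of this step. From the compounds shown here alone, whether the loss of the ring or of the bromine matters more stays open, as does how an unsubstituted phenyl, a shorter chain or an amine-bearing chain would read here.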